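The source may report more compounds than this note shows. Statements on the series, on what has been measured and on what is new or still open speak of the compounds shown alone.

Measured compounds:
compound 1 `C/C(=N\NC(=O)COc1cccc2ccccc12)c1ccc(C#N)cc1Br`: 20 ug/mL
compound 2 `Cc1ccc(/C=N/NC(=O)COc2cccc3ccccc23)cc1`: 20 ug/mL

Both were tested in an ADME assay on HEL cells (Homo sapiens) for cytotoxicity; a higher number here means that more compound is tolerated, a lower number that less compound is tolerated. Compound 1 gives 20 ug/mL and compound 2 gives 20 ug/mL; the two sit level with each other, and their difference lies within the usual scatter. Compound 3 `C/C(=N\NC(=O)COc1cccc2ccccc12)c1ccc(O)cc1` has not yet been measured. It differs from compound 1 in one place: 4-hydroxyphenyl in place of 2-bromo-4-cyanophenyl on a carbon with a double bond to nitrogen. Among the compounds with values here, no measured pair shows the effect of this change, so no direction is expected, and the step is expected to stay within the scatter. The estimate for compound 3 in this assay is 20 ug/mL, with a range from 10 ug/mL to 50 ug/mL. This estimate means an expected step of no change at the digits printed from compound 1 to compound 3 (within the scatter).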

Compound 3, minimum cytotoxic concentration: 20 ug/mL
Compound 3: middle estimate and measured number agree at the digits printed; the range from low to high includes it.
By their numbers in this assay, from the lowest: compounds 1, 2 and 3 (each within the scatter of the next).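

In this assay, the change to 4-hydroxyphenyl gives no change at the digits printed from compound 1 to compound 3 (within the scatter). Within the data shown here, this is the first step read at this position, and it shows that replacing 2-bromo-4-cyanophenyl on a carbon with a double bond to nitrogen leaves the read-out within the scatter, even though the bromine and nitrile leave together. No measurement on hand explains this outcome.

Going by these compounds, because the groups changed together, the separate contributions of the bromine, the nitrile and the hydroxyl remain open. Whether a ring bearing an amine or a carboxylic acid would also stay level is open too.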